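Swapping the ring attachment point on compound 3

The source may hold more compounds than are shown below. What is called first, only, known or untested is meant among the compounds shown, and "the series" means these compounds.

This series shares a core carrying a basic side chain, and it was followed in an ADME assay on microsomes from liver (Homo sapiens) for metabolic stability, read by LC-MS, with a stated time of 10 min, tested at 0.5 uM; a higher number here means that more of the compound is left, a lower number that less of the compound is left. Compound 1 `CN1CCN(CCCN(C[C@H]2Cc3ccccc3CN2)[C@H]2CCCc3cccnc32)CC1` gives 72%, compound 2 `CCN1CCN(CCCN(C[C@H]2Cc3ccccc3CN2)[C@H]2CCCc3cccnc32)CC1` gives 59%, and compound 3 `c1ccc2c(c1)CN[C@@H](CN(CCC1CCNCC1)[C@H]1CCCc3cccnc31)C2` gives 66%. Compound 3 stands second highest of the three, with compound 1 and compound 2 both within the scatter of it. The next compound, compound 4 `c1ccc2c(c1)CN[C@@H](CN(CC[C@@H]1CCCNC1)[C@H]1CCCc3cccnc31)C2`, differs from compound 3 only by piperidin-3-yl in place of piperidin-4-yl on a saturated chain carbon, two bonds along the chain from an amine nitrogen.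

Going by the values given here, no measured step makes this exact change. Among the compounds with values here, the two steps that touch the same chain end, a number 6 percentage points lower from compound 1 to compound 3 (within the scatter) and a number 7 percentage points higher from compound 2 to compound 3 (within the scatter), both stayed within the scatter, and the one step beyond it, a number 13 percentage points lower from compound 1 to compound 2 (beyond the scatter), concerns a different part of the molecule. With so little to go on, no movement beyond the scatter is expected for compound 4 in this assay, and the estimated step is no change at the digits printed from compound 3 to compound 4 (within the scatter). Compound 4 is therefore expected to give about 66%, somewhere between 50% and 80%.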

Compound 4, percent of the compound remaining: 75%
Compound 4: middle estimate off by 9 percentage points, on the low side; the measured number falls inside the stated range.
By their numbers in this assay, from the lowest: compounds 2, 3, 1 and 4 (each within the scatter of the next, the first and the last beyond it).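

In this assay, swapping the attachment point of the ring, with piperidin-3-yl in place of piperidin-4-yl, gives a number 9 percentage points higher from compound 3 to compound 4 (within the scatter) and so shows that these same atoms, joined differently, stay within the usual scatter at this position. Compared with the piperazine side chains, piperidin-3-yl in place of (4-ethylpiperazin-1-yl)methyl gives a number 16 percentage points higher from compound 2 to compound 4 (beyond the scatter) and opens a gap that compound 3 did not show against compound 2, while piperidin-3-yl in place of (4-methylpiperazin-1-yl)methyl gives a number 3 percentage points higher from compound 1 to compound 4 (within the scatter) and leaves no such gap. Nothing available explains these numbers.

The compounds shown leave open how piperidin-2-yl would read at this position. They also leave open what the opposite arrangement at the defined stereocentre of piperidin-3-yl, or a methyl on its ring nitrogen, would do.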